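The source may hold more compounds than are shown below. What is called first, only, known or untested is meant among the compounds shown, and "the series" means these compounds.

Compound 1 `C=C1C(=O)O[C@H]2[C@H]1CC/C(COC(=O)Cn1cc(F)c(=O)[nH]c1=O)=C\CC[C@@]1(C)O[C@@H]21`: > 20000 nM (a limit)
Compound 2 `C=C1C(=O)O[C@H]2[C@H]1CC/C(COC(=O)Cn1cc(F)c(=O)n(Cc3ccc(F)cc3F)c1=O)=C\CC[C@@]1(C)O[C@@H]21`: 5010 nM

Going by the values given here, in a functional assay on Bel7402/5-FU cells (Homo sapiens) for antiproliferative activity, read by MTT assay, with a stated time of 72 h (a higher number here means a weaker inhibitor, a lower number a stronger inhibitor), compound 2 holds the only true number, 5010 nM. Compound 1 gives > 20000 nM, which is a limit of the assay and not a number. Placing 2,4-difluorobenzyl in place of hydrogen on an aromatic nitrogen produced an at least 3.9-fold lower number from compound 1 to compound 2 (0.60 log units; beyond the scatter), a step beyond the scatter. Compound 3 `C=C1C(=O)O[C@H]2[C@H]1CC/C(COC(=O)Cn1cc(F)c(=O)n(Cc3c(F)cccc3F)c1=O)=C\CC[C@@]1(C)O[C@@H]21` keeps the same atoms, joined differently: 2,6-difluorophenyl in place of 2,4-difluorophenyl on a saturated chain carbon bound to an aromatic nitrogen. That single measured step bears on the benzyl group as a whole, but none compares one difluorophenyl pattern with another. The substitution therefore gives no firm reason to expect a real shift in this assay from compound 2 at 5010 nM. The expected change is a 1.2-fold higher number from compound 2 to compound 3 (0.08 log units; within the scatter), which would lie within the scatter. For compound 3, the estimated value is 6000 nM, with an expected range of 2500 nM to 15000 nM.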

Compound 3, half-maximal inhibitory concentration: 4980 nM
Beside the measured number, compound 3's estimate is 1.2-fold (0.08 log units) above it, and the stated range covers the measured number.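

In this assay, going by these compounds alone, 2,6-difluorophenyl in place of 2,4-difluorophenyl on a saturated chain carbon bound to an aromatic nitrogen gave a 1.0-fold lower number from compound 2 to compound 3 (0.00 log units; within the scatter), the first direct comparison of one difluorophenyl pattern with another, and here the two patterns cannot be told apart. Replacing the hydrogen on the aromatic nitrogen with a 2,6-difluorobenzyl group gave an at least 4.0-fold lower number from compound 1 to compound 3 (0.60 log units; beyond the scatter), so the step beyond the scatter now holds for two difluorobenzyl groups rather than one. The full size of both steps from compound 1 cannot be read because compound 1 stands at a limit: the limit of > 20000 nM in this assay, at which 1 of the 3 values shown sits.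

As far as these compounds go, it remains open what an unsubstituted benzyl, a methoxybenzyl or a plain ethyl chain would give on that nitrogen. From the compounds shown here alone, it is therefore also open whether the fluorines contribute to the step at all.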